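A few compounds are considered here, and "the series" means these few. Any claim that something is new, unique, unknown or untested is made for them only; others in the source may bear on it.

Measured so far in an ADME assay on Akata cells (Homo sapiens) for cytotoxicity, with a stated time of 7 days (a higher number here means that more compound is tolerated, a lower number that less compound is tolerated), all three values being limits:
- Compound 1 `Nc1nc(NCc2ccccc2)c2ncn(/C=C3/CC3(CO)CO)c2n1`: > 24000 nM
- Compound 2 `CCCNc1nc(N)nc2c1ncn2/C=C1/CC1(CO)CO`: > 24000 nM
- Compound 3 `Nc1nc(NC2CCCC2)c2ncn(/C=C3/CC3(CO)CO)c2n1`: > 20000 nM

Compound 3 stands at the limit of > 20000 nM in this assay, at which 1 of the 3 values shown sits. Compounds 1 and 2 stand at the limit of > 24000 nM in this assay, at which 2 of the 3 values shown sit.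

Compound 4 `CC(C)CNc1nc(N)nc2c1ncn2/C=C1/CC1(CO)CO` carries isobutyl in place of cyclopentyl on a nitrogen on an aromatic ring.

For the measured compounds named here, three measured steps bear on this change. The closest is a step that the two limits leave unreadable from compound 2 to compound 3, which joins cyclopentyl and propyl on that nitrogen. The others are a step that the two limits leave unreadable from compound 1 to compound 3 and a step that the two limits leave unreadable from compound 1 to compound 2. Going by the values given here, none of them gives a size, so no measured step points in either direction. Compound 2, with its open propyl chain, gives > 24000 nM, which is a limit. Compound 3, with its cyclopentyl ring, gives > 20000 nM, which is also a limit. No step beyond the usual scatter is therefore expected in this assay, and compound 4 will probably also be reported only as a limit.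

The expected change is a step that the limit leaves unreadable from compound 3 to compound 4. For compound 4 the estimate is 24000 nM, with an expected range of 14000 nM to 40000 nM.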

Compound 4, half-maximal cytotoxic concentration: > 24000 nM
Compound 4 gave a limit, no number (the forecaster's own chance of this, stated with the estimate: 85%); the middle value sits exactly at the limit.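

In this assay compound 4 gives > 24000 nM, which is a limit, so its steps from compounds 1, 2 and 3 cannot be read. The compounds shown leave open whether the groups on the nitrogen on an aromatic ring make any difference in this assay.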